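The source may report more compounds than this note shows. Statements on the series, on what has been measured and on what is new or still open speak of the compounds shown alone.

Of the compounds shown here, three have so far been measured in a functional assay on cells (T-cell, Mus musculus, strain BALB/c) for inhibition, read by MTT assay, with stated times of 24 h and 72 h; on this read-out higher numbers stand for weaker inhibition and lower numbers for stronger inhibition. Compound 1 `COc1cc(-c2nnc(SCc3ccccc3[N+](=O)[O-])o2)ccc1O` gives 9600 nM, compound 2 `COc1cc(-c2nnc(SCc3cccc([N+](=O)[O-])c3)o2)ccc1O` gives 16000 nM, and compound 3 `COc1cc(-c2nnc(SCc3cccc(Cl)c3)o2)ccc1O` gives 8290 nM. Compound 3 shows the lowest of the three numbers, but its gap to compound 1 and its gap to compound 2 both fall within the usual scatter of repeated measurements, so the three cannot be separated in strength on this evidence.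

Compound 4 `COc1cc(-c2nnc(SCc3ccc(Br)cc3)o2)ccc1O` has not yet been measured. The change from compound 3 is 4-bromophenyl in place of 3-chlorophenyl on a saturated chain carbon bound to a sulfur.

For the measured compounds named here, only one single-point step among the measured compounds offers any guidance: a 1.9-fold lower number from compound 2 to compound 3 (0.29 log units; within the scatter). That step replaced a nitro with a chloro on the same ring and left the number within the scatter. It does not test a change of this kind, in which one ring bearing chlorine gives way to another ring bearing bromine, so it is a weak guide, and nothing else measured here speaks to the exchange at all.

Given that thin basis, the step of a 1.0-fold lower number from compound 3 to compound 4 (0.02 log units; within the scatter) is expected to stay within the scatter. Compound 4 is therefore estimated at 8000 nM, with a range from 3500 nM to 18000 nM.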

Compound 4, half-maximal inhibitory concentration: 8830 nM
Estimate against measurement, compound 4: 1.1-fold (0.04 log units) below; the range from low to high includes it.
By their numbers in this assay, from the lowest: compounds 3, 4, 1 and 2 (each within the scatter of the next).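

In this assay, the exchange of 3-chlorophenyl for 4-bromophenyl on a saturated chain carbon bound to a sulfur gives a 1.1-fold higher number from compound 3 to compound 4 (0.03 log units; within the scatter), so this second kind of change at the group also leaves the number within the scatter. For the compounds shown here, the earlier step, a 1.9-fold lower number from compound 2 to compound 3 (0.29 log units; within the scatter), swapped only one substituent on the ring, whereas here both the halogen and its place on the ring differ, and the result gives no sign that this combined change matters; it also cannot separate the two changes, which might have small opposing effects or none at all. No other measurement is at hand to explain this result.

Still open, on these data alone, is whether any group at this place can move the number beyond the scatter, for example a phenyl ring carrying an amine or a carboxylic acid, or a longer chain between the sulfur and the ring. Also open, as far as these compounds go, is how the halogen and its ring location would each behave if varied alone, such as 4-chlorophenyl or 3-bromophenyl.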